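The compounds below may be only part of what the source reports. "The series", "measured", "known", "first", "only" and "open" are said of these compounds alone.

Compound 2, `CCCCCCCc1ccc(NC(=O)N[C@@H](C)c2ccccc2)cc1`, sits at 100% in an ADME assay on the whole organism with Oryza sativa as the target, tested at 0.1 uM (a lower number here means a stronger effect, a higher number a weaker effect of the compound at the concentration tested), the highest of the two numbers measured, with compound 1, `CC(C)c1ccc(NC(=O)N[C@@H](C)c2ccccc2)cc1`, nearest at 98%; the two values lie within the scatter of one another. Among the measured compounds shown here, the one measured step, a number 2 percentage points higher from compound 1 to compound 2 (within the scatter), replaced one alkyl chain with another and left this assay unchanged beyond its scatter. Compound 3, `CCOC(=O)c1ccc(NC(=O)N[C@@H](C)c2ccccc2)cc1`, differs from compound 2 by ethoxycarbonyl in place of heptyl on an aromatic carbon. For the measured compounds named here, no measured step bears on swapping an alkyl chain for an ethoxycarbonyl group; the only step available concerns two alkyl chains and was within the scatter. Both measured values also sit near the top of the scale. Compound 3 is therefore expected to give about 95%, within 80% to 103%, a step of a number 5 percentage points lower from compound 2 to compound 3 (within the scatter) that is expected to stay within the scatter.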

Compound 3, a percentage reported as activity, at one concentration (the size of the read-out at that concentration, not a potency): 99%
The estimate for compound 3 lay 4 percentage points below the measured number; low and high end bracket the measured number.
By their numbers in this assay, from the lowest: compounds 1, 3 and 2 (each within the scatter of the next).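

Ethoxycarbonyl in place of heptyl on the aromatic carbon gave a number 1 percentage points lower from compound 2 to compound 3 (within the scatter) in this assay, and ethoxycarbonyl in place of isopropyl gave a number 1 percentage points higher from compound 1 to compound 3 (within the scatter). The position para to a large group has therefore now taken a group with two hydrogen-bond acceptors and a double bond outside the aromatic rings, as well as two alkyl chains, and this assay does not separate any of the three. Nothing available accounts for why these three groups read alike.

From the compounds shown here alone, whether an amine, a carboxylic acid or a chlorine atom at this place would move the number in this assay beyond the scatter stays open. So does whether a change elsewhere on the shared core would do so.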